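Moving the hydroxyl one carbon further out along the alkyne chain

The source may report more compounds than this note shows. Statements on the series, on what has been measured and on what is new or still open speak of the compounds shown alone.

Compound 2 `CC(O)C#Cc1c(Cl)c2c(Cl)cc(C(N)=O)nc2n1[C@H]1CCCNC1` gives 206000 nM in a physicochemical assay for solubility, measured as thermodynamic solubility, at pH 7.4; on this read-out lower numbers stand for lower solubility and higher numbers for higher solubility. Compound 1 `NC(=O)c1cc(Cl)c2c(Cl)c(C#CCCO)n([C@H]3CCCNC3)c2n1` gives 144000 nM in this assay, and the step of a 1.4-fold higher number from compound 1 to compound 2 (0.16 log units; within the scatter) is within the scatter, so the two compounds sit side by side rather than one ahead of the other.

Compound 3 `CC(O)CC#Cc1c(Cl)c2c(Cl)cc(C(N)=O)nc2n1[C@H]1CCCNC1` has not yet been measured. It differs from compound 2 by 2-hydroxypropyl in place of 1-hydroxyethyl on a triple-bonded carbon. Going by the values given here, the only measured step that bears on this change is the one from compound 1 to compound 2, where the hydroxyl group was shifted along the chain attached to the triple bond and the number in this assay stayed within the scatter. The change to compound 3 is of the same kind: the hydroxyl again moves along that chain, and one carbon is added.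

On that basis, the step of a 1.0-fold lower number from compound 2 to compound 3 (0.01 log units; within the scatter) is expected to stay within the scatter. Compound 3 is therefore estimated to give about 200000 nM in this assay, with a range from 100000 nM to 400000 nM.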

Compound 3, solubility: 760000 nM
Compound 3: the middle estimate sits 3.8-fold (0.58 log units) below what was measured; the whole stated range lies below it.
By their numbers in this assay, from the lowest: compounds 1 and 2 (each within the scatter of the next); then compound 3.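

The alkyne chain is not as indifferent as the earlier pair made it look: replacing 1-hydroxyethyl with 2-hydroxypropyl on a triple-bonded carbon gives a 3.7-fold higher number from compound 2 to compound 3 (0.57 log units; beyond the scatter) in this assay and so, unlike the first shift of the hydroxyl, moves the number beyond the scatter. The same structure can also be read as methyl in place of hydrogen on a saturated chain carbon bound to an oxygen, a small addition that goes with a 5.3-fold higher number from compound 1 to compound 3 (0.72 log units; beyond the scatter) and leaves compound 3 clearly apart from the other two, although the groups that leave and enter carry the same counts of hydrogen-bond donors and acceptors and no net charge. Nothing shown here gives a measured property that would explain this rise.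

These three compounds cannot separate the effect of the added carbon from that of where the hydroxyl sits on the chain, since the two change together on the way to compound 3. From the compounds shown here alone, whether a longer chain, or an amine or a carboxylic acid in place of the hydroxyl, would raise the number further or lower it remains open.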